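The source may hold more compounds than are shown below. What is called first, only, known or untested is meant among the compounds shown, and "the series" means these compounds.

Compound 3 `CC(C)c1cc(C(C)(C)C)cc(-c2cccc(-c3ccccc3)c2)c1CO` gives 210 nM in a functional assay on RKE cells for antagonist activity at Vasoactive intestinal polypeptide receptor 1 (Rattus norvegicus), read by HTRF and cAMP accumulation, with stated times of 10 min and 30 min (a higher number here means a weaker inhibitor, a lower number a stronger inhibitor), the lowest of the two numbers shown; compound 2 `Cc1cccc(-c2cc(C(C)(C)C)cc(C(C)C)c2CO)c1` gives 240 nM, which lies within the scatter of it. Compound 1 `CC(C)c1cc(C(C)(C)C)cc(-c2cccc(C(F)(F)F)c2)c1CO` reaches only the limit of > 50000 nM in this assay. Compound 4 `COc1cccc(-c2cc(C(C)(C)C)cc(C(C)C)c2CO)c1` differs from compound 3 by methoxy in place of phenyl on an aromatic carbon. For the measured compounds named here, two measured steps touch this position: an at least 230-fold lower number from compound 1 to compound 3 (2.37 log units; beyond the scatter), a large step, and a 1.1-fold lower number from compound 2 to compound 3 (0.06 log units; within the scatter), a step within the scatter. A methyl and a phenyl thus give much the same number here, and only the trifluoromethyl drops out. Methoxy is neither of these, so a step of modest size at most is expected for compound 4, a 1.7-fold higher number from compound 3 to compound 4 (0.22 log units; within the scatter). Compound 4 is estimated at 350 nM, with a range from 120 nM to 1500 nM.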

Compound 4, half-maximal inhibitory concentration: 200 nM
Compound 4: the middle estimate sits 1.8-fold (0.24 log units) above what was measured; the measured number falls inside the stated range.
By their numbers in this assay, from the lowest: compounds 4, 3 and 2 (each within the scatter of the next). At a limit, above all of these: compound 1.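

Methoxy has far fewer heavy atoms than phenyl and carries a hydrogen-bond acceptor, yet the result is a 1.1-fold lower number from compound 3 to compound 4 (0.02 log units; within the scatter). Against methyl it is a 1.2-fold lower number from compound 2 to compound 4 (0.08 log units; within the scatter), so among these three groups neither difference shows up in the number. Trifluoromethyl alone goes against this pattern: compound 1 sits at a limit of the assay, not at a number, giving an at least 250-fold lower number from compound 1 to compound 4 (2.39 log units; beyond the scatter). Going by these compounds, how a chlorine, a nitrile or an amine on this aromatic carbon would fare stays open, and so does whether the loss is peculiar to trifluoromethyl.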